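Removing one carbonyl from the five-membered ring of compound 1

This account rests on a few compounds, and the source may have more. Where it says the series, first, only, none or still open, it means among the compounds named here.

Measured compounds:
- compound 1 `CCc1cnc(N2CCC(c3nc(COc4ccc(/C=C5\CC(=O)NC5=O)cc4F)cs3)CC2)nc1`: 49 nM
- compound 2 `CCc1cnc(N2CCC(c3nc(COc4ccc(/C=C5\CC(=O)NC5=O)cc4)cs3)CC2)nc1`: 182 nM
- compound 3 `CCc1cnc(N2CCC(c3nc(COc4c(F)cc(/C=C5\CC(=O)NC5=O)cc4F)cs3)CC2)nc1`: 211 nM

All three were tested in a functional assay on cells for agonist activity at Glucose-dependent insulinotropic receptor (Homo sapiens), read by a luciferase reporter, with a stated time of 6 h; on this read-out higher numbers stand for an effect only at larger amounts of compound and lower numbers for an effect already at smaller amounts. Compound 1 has the lowest number of the three. Its nearest neighbour is compound 2, reached by a 3.7-fold higher number from compound 1 to compound 2 (0.57 log units; beyond the scatter), and the furthest is compound 3, reached by a 4.3-fold higher number from compound 1 to compound 3 (0.63 log units; beyond the scatter). Both of these steps change only a fluoro on the aromatic ring that carries the five-membered ring group; both push the number up by a modest amount.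

Compound 4 `CCc1cnc(N2CCC(c3nc(COc4ccc(/C=C5\CCNC5=O)cc4F)cs3)CC2)nc1` is not yet measured. It differs from compound 1 in a different place: a group of 7 heavy atoms (5 carbon, 1 nitrogen, 1 oxygen; one five-membered non-aromatic ring with 1 hetero atom) in place of a group of 8 heavy atoms (5 carbon, 1 nitrogen, 2 oxygen; one five-membered non-aromatic ring with 1 hetero atom), on an aromatic carbon. The two measured steps concern fluoro, not this ring group, so none of them bears on the change from compound 1 to compound 4, and the direction of the step has to be taken as open. With the ring group altered but the rest of the molecule kept, a modest rise in the number is taken as the most likely outcome, with a wide margin either way.

For compound 4 in this assay the expected value is 150 nM, between 30 nM and 800 nM. The step this estimate implies is a 3.1-fold higher number from compound 1 to compound 4 (0.49 log units; beyond the scatter), and it is an expectation only.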

Compound 4, half-maximal effective concentration: 100 nM
Estimate against measurement, compound 4: 1.5-fold (0.18 log units) above; the measured number falls inside the stated range.
By their numbers in this assay, from the lowest: compound 1; then compounds 4, 2 and 3 (each within the scatter of the next, the first and the last beyond it).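

Among the compounds shown here, the five-membered ring group itself is changed here for the first time, as the earlier steps touched only the fluoro. In this assay the loss of one carbonyl from this ring, on an aromatic carbon para to a large group, gives a 2.0-fold higher number from compound 1 to compound 4 (0.31 log units; beyond the scatter) and so has a real but modest effect. That carbonyl therefore contributes to the low number of compound 1 but is not essential for activity at the receptor, since compound 4 still acts at a nanomolar concentration. No measurement is available to explain why the step has this size.

As far as these compounds go, it remains open whether the other carbonyl of the ring matters more, and whether a ring with an amine, or an open-chain group such as a carboxylic acid or a primary amide, would be accepted at this position. From the compounds shown here alone, it is also open whether the fluoro effect seen in a 3.7-fold higher number from compound 1 to compound 2 (0.57 log units; beyond the scatter) carries over to the ring of compound 4, since the fluoro and the ring group have so far been varied only one at a time.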